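Series notes: side chain on the imidazole nitrogen, compound 4

This account rests on a few compounds, and the source may have more. Where it says the series, first, only, none or still open, it means among the compounds named here.

Compound 3 `CC(C)(C)Cc1cnc(CCc2ccc(-c3cccc(F)c3C(=O)O)cc2)n1CCOc1cccc(O)c1` gives 0.9 nM in an assay on cells for agonist activity at Bombesin receptor subtype-3 (Homo sapiens), read by HTRF and inositol phosphate accumulation, with a stated time of 1 h (a lower number here means that less compound is needed, a higher number that more compound is needed for the effect), the lowest number of the three measured. Compound 2 `CC(C)(C)Cc1cnc(CCc2ccc(-c3cccc(F)c3C(=O)O)cc2)n1CCO` gives 3 nM, and compound 1 `CC(C)(C)Cc1cnc(CCc2ccc(-c3cccc(F)c3C(=O)O)cc2)n1CCC(=O)O` gives 11 nM. The steps are a 3.7-fold lower number from compound 1 to compound 2 (0.56 log units; beyond the scatter), a 3.3-fold lower number from compound 2 to compound 3 (0.52 log units; beyond the scatter) and a 12-fold lower number from compound 1 to compound 3 (1.09 log units; beyond the scatter).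

Compound 4 `CC(C)(C)Cc1cnc(CCc2ccc(-c3cccc(F)c3C(=O)O)cc2)n1CCNS(C)(=O)=O` differs from compound 3 by methanesulfonamido in place of 3-hydroxyphenoxy on a saturated chain carbon, two bonds along the chain from an aromatic nitrogen. The step that bears on it most directly is a 3.3-fold lower number from compound 2 to compound 3 (0.52 log units; beyond the scatter), which shows that removing the 3-hydroxyphenyl from the oxygen costs a modest amount; compound 4 keeps a small polar group at that place, more like compound 2 than compound 3. The step of a 3.7-fold lower number from compound 1 to compound 2 (0.56 log units; beyond the scatter) shows that the identity of the small group at this place also matters modestly. Among the measured compounds shown here, no measured compound carries a sulfonamide here.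

Compound 4 is therefore expected to give a modestly higher number than compound 3, estimated as a 3.9-fold higher number from compound 3 to compound 4 (0.59 log units; beyond the scatter), landing near compound 2. The estimate for compound 4 in this assay is 3.5 nM, with a range from 1 nM to 12 nM.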

Compound 4, half-maximal effective concentration: 2 nM
The estimate for compound 4 lay 1.8-fold (0.24 log units) above the measured number; measured number inside the range.
By their numbers in this assay, from the lowest: compound 3; then compounds 4 and 2 (each within the scatter of the next); then compound 1.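

Notes on the side chain, read in this assay: replacing 3-hydroxyphenoxy with methanesulfonamido at this chain carbon gives a 2.2-fold higher number from compound 3 to compound 4 (0.35 log units; beyond the scatter), so a group with no ring stays within a modest step of the lowest number in the set. Against hydroxy at the same place the step is a 1.5-fold lower number from compound 2 to compound 4 (0.18 log units; within the scatter), and these two groups cannot be told apart in this assay. Against carboxy the step is a 5.5-fold lower number from compound 1 to compound 4 (0.74 log units; beyond the scatter), so among the three groups without a ring, carboxy alone stands apart from the other two.

From the compounds shown here alone, whether the lower number of compound 3 follows from its aromatic ring or from the hydroxy on that ring stays open, as does the outcome for a primary amine, a carboxamide or a longer chain at this place. Nothing available accounts for these steps.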